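Chloro in Place of Fluoro: A Small Step Expected

The source may report more compounds than this note shows. Statements on the series, on what has been measured and on what is new or still open speak of the compounds shown alone.

Of the compounds shown here, three that share one core have been tested in a functional assay on the whole organism with Mus musculus as the target, in the maximal electroshock model, with a stated time of 0.5 h; a higher number here means that more compound is needed for the effect, a lower number that less compound is needed. Compound 1, `O=C(CNc1ccc(F)cc1)Nc1nc2ccc(Cl)cc2s1`, needs 100 mg/kg. Compound 2, `Fc1ccc(/C=N/NC(=S)Nc2nc3ccc(Cl)cc3s2)cc1`, needs 30 mg/kg. Compound 3, `O=C(Cn1ccnc1)Nc1nc2ccc(Cl)cc2s1`, needs 30 mg/kg. Compound 2 stands level with compound 3 at the digits shown, and together they give the lowest numbers of the three; compound 1 lies a step higher, and that step is beyond the usual scatter of this kind of measurement.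

Compound 4, `S=C(N/N=C/c1ccc(Cl)cc1)Nc1nc2ccc(Cl)cc2s1`, has not yet been measured. It differs from compound 2 in one place only: chloro in place of fluoro on an aromatic carbon.

Going by the values given here, no measured pair in this set differs by just this swap, so there is no direct yardstick for the step. One heavy atom leaves and one enters, with no ring, no hydrogen-bond donor or acceptor and no charge gained or lost, so the step is expected to stay within the usual scatter, with no clear direction. Compound 4 is therefore expected to give about 30 mg/kg, in a range from 15 mg/kg to 60 mg/kg. That estimate amounts to no change at the digits printed from compound 2 to compound 4 (within the scatter).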

Compound 4, minimum effective dose: 300 mg/kg
Estimate against measurement, compound 4: 10-fold (1.00 log units) below, and the stated range ends below it.
By their numbers in this assay, from the lowest: compounds 2 and 3 (each within the scatter of the next); then compound 1; then compound 4.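

In this assay the swap on this aromatic carbon, para to a large group, proves far from small: going from 4-fluorophenyl to 4-chlorophenyl gives a 10-fold higher number from compound 2 to compound 4 (1.00 log units; beyond the scatter) and this step lies beyond the scatter. Going by these compounds alone, it is the first pair in the set to differ in one place only, so it gives the first direct sign that the dose needed can depend strongly on which halogen sits at a single position. The two groups match in every count available here, with one heavy atom each and no ring, hydrogen-bond donor, hydrogen-bond acceptor or charge, so those counts did not foresee this step, and nothing measured here accounts for it.

As far as these compounds go, with only these two halogens at this position, it remains open whether fluoro is unusually favourable or chloro unusually unfavourable, and a hydrogen, a methyl or a methoxy group at the same carbon would help to separate the two. From the compounds shown here alone, it is also open whether the same swap would have a similar effect on compound 1, which carries the 4-fluorophenyl group on a different linker.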